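A few compounds are considered here, and "the series" means these few. Any claim that something is new, unique, unknown or untested is made for them only; others in the source may bear on it.

Compound 1 `Nc1ccccc1NC(=O)CCCNCC(=O)Nc1ccc(Br)cc1`: > 100000 nM, a limit.
Compound 2 `Nc1ccccc1NC(=O)c1ccc(NCC(=O)Nc2ccc([N+](=O)[O-])cc2)cc1`: > 100000 nM, a limit.

In a functional assay on U-251 cells (Homo sapiens) for inhibition, read by MTT assay, with a stated time of 2 days (on this read-out lower numbers stand for higher toxicity in this test and higher numbers for lower toxicity in this test), compound 2 gives > 100000 nM, which is a limit and not a number. All the series offers so far is the limit of > 100000 nM in this assay, at which 2 of the 2 values shown sit. Among the measured compounds shown here, no measured pair differs in one place only, so the series shows no size of change for any single structural edit.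

The next compound to be read is compound 3 `COc1ccc(NC(=O)CNc2ccc(C(=O)Nc3ccccc3N)cc2)cc1`. It keeps the rest of compound 2 and carries methoxy in place of nitro on an aromatic carbon, para to a large group, so that 4-nitrophenyl becomes 4-methoxyphenyl: methoxy in place of nitro on an aromatic carbon.

The expectation rests on compound 2, whose reading of > 100000 nM is a limit. In this assay the estimated step of a number no higher from compound 2 to compound 3 (the limit leaves the size open) is expected to stay within the scatter, with no direction favoured. Another reading that is only a limit is the likely outcome for compound 3. As a number, compound 3 is estimated at 100000 nM, with an expected range of 30000 nM to 200000 nM.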

Compound 3, concentration lethal to 50% of the cells: > 100000 nM
Compound 3 ended at the assay's limit (the forecaster's own chance of this, stated with the estimate: 70%); the middle value lies on the limit itself.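

In this assay no step can be read between compound 2 and compound 3, because both readings are limits and not numbers: the limit of > 100000 nM in this assay, at which 3 of the 3 values shown sit.

The compounds shown leave open what size of change methoxy in place of nitro brings, and whether any compound in this series gives a measurable value in this assay.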